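The source may hold more compounds than are shown below. What is called first, only, known or untested is meant among the compounds shown, and "the series" means these compounds.

The measured compounds and their numbers:
compound 1, `COc1ccc(N(C)c2nc(C)nc3ccccc23)cc1C(=O)NCC[Se]C#N`, gives 187 nM in a functional assay on A549 cells (Homo sapiens) for inhibition, read by MTT assay, with a stated time of 48 h; on this read-out lower numbers stand for stronger inhibition and higher numbers for weaker inhibition;
compound 2, `COc1ccc(N(C)c2nc(C)nc3ccccc23)cc1C(=O)OCCCCC[Se]C#N`, gives 592 nM;
compound 3, `COc1ccc(N(C)c2nc(C)nc3ccccc23)cc1`, gives 3 nM.

Compound 3 stands at the lowest number of the three, meaning the strongest inhibition of the cells. Its nearest neighbour is compound 1, and the step of a 62-fold lower number from compound 1 to compound 3 (1.79 log units; beyond the scatter) lies well beyond the scatter. Compound 2 is further away still, with compound 2 at 592 nM against compound 3 at 3 nM.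

Compound 4, `COc1ccc(N(C)c2nc(C)nc3ccccc23)cc1C(=O)OCCCC[Se]C#N`, is compound 3 with a group of 10 heavy atoms (6 carbon, 1 nitrogen, 2 oxygen, 1 selenium; no ring) in place of a hydrogen atom, on an aromatic carbon; the new group sits ortho to a methoxy group and meta to a large group. For the measured compounds named here, two measured steps bear on this. Read backwards, a 62-fold lower number from compound 1 to compound 3 (1.79 log units; beyond the scatter) shows that attaching a selenium-bearing chain through a carbonyl to the bare core raises the number greatly. Then a 3.2-fold higher number from compound 1 to compound 2 (0.50 log units; beyond the scatter) shows that replacing the amide-linked chain by a longer ester-linked chain raises it modestly further. The chain of compound 4 is ester-linked and shorter than that of compound 2, so a large upward step is expected, a 130-fold higher number from compound 3 to compound 4 (2.12 log units; beyond the scatter), landing between compound 1 and compound 2. Compound 4 is therefore estimated at 400 nM, in the range 150 nM to 1000 nM.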

Compound 4, half-maximal inhibitory concentration: 155 nM
Compound 4: middle estimate off by 2.6-fold (0.41 log units), on the high side; low and high end bracket the measured number.
By their numbers in this assay, from the lowest: compound 3; then compounds 4 and 1 (each within the scatter of the next); then compound 2.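

In this assay, the large rise also appears with an ester-linked chain on this aromatic carbon, ortho to a methoxy group: a 52-fold higher number from compound 3 to compound 4 (1.71 log units; beyond the scatter) shows that the loss of inhibition does not depend on an amide link, as compound 1 alone could not show. Chain length within the ester-linked pair also makes a difference, since a 3.8-fold lower number from compound 2 to compound 4 (0.58 log units; beyond the scatter) is modest but beyond the scatter, with the shorter chain of compound 4 giving the lower number. Against the amide-linked chain, a 1.2-fold lower number from compound 1 to compound 4 (0.08 log units; within the scatter) lies within the scatter, so these two compounds cannot be told apart, although their chains differ in both link and length.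

No supporting measurement accompanies these numbers, so they record the size of each change and say nothing of its origin. Still open, going by these compounds, is whether a shorter ester-linked chain, an amide-linked chain of the same length as in compound 4, or a simple carboxylic acid on this carbon would come closer to compound 3 at 3 nM, and how much of the rise comes from the selenium-bearing nitrile end of the chain.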